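From a Sulfur Link to an Oxygen Link in Compound 3

A few compounds are considered here, and "the series" means these few. Any claim that something is new, unique, unknown or untested is made for them only; others in the source may bear on it.

Compound 1 `COc1ccc(Sc2nc3cc(N)cc(N)c3nc2-c2ccccc2)cc1`: < 100000 nM in this assay, a limit.
Compound 2 `Nc1cc(N)c2nc(-c3ccccc3)c(Sc3ccc(Cl)c(Cl)c3)nc2c1`: < 100000 nM in this assay, a limit.

In a functional assay on UACC-62 cells (Homo sapiens) for inhibition, read by sulforhodamine B assay, with a stated time of 48 h (on this read-out lower numbers stand for higher toxicity in this test and higher numbers for lower toxicity in this test), compound 1 gives < 100000 nM, which is a limit of the assay and not a number. In the same test compound 2 gives < 100000 nM, again a limit rather than a number. Among the measured compounds shown here, the one measured step, a step that the two limits leave unreadable from compound 1 to compound 2, therefore cannot be read in size or direction. Compound 2 stands at the limit where both shown values sit (the limit of < 100000 nM in this assay, at which 2 of the 2 values shown sit). Compound 3 `Nc1cc(N)c2nc(-c3ccccc3)c(Oc3ccc(F)cc3)nc2c1` differs from compound 2 in one place: 4-fluorophenoxy in place of (3,4-dichlorophenyl)sulfanyl on an aromatic carbon. For the measured compounds named here, the only measured step bears on a change at the same sulfur position but yields no readable size, so no step beyond the usual scatter is expected in either direction, and a step that the limit leaves unreadable from compound 2 to compound 3 is offered as an estimate only. Compound 3 is thus expected to give about 40000 nM, within 8000 nM to 100000 nM.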

Compound 3, concentration lethal to 50% of the cells: 69200 nM
For compound 3 the middle estimate is 1.7-fold (0.24 log units) below the measured one; low and high end bracket the measured number.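

No step from compound 1 or compound 2 to compound 3 can be read, as the values of compound 1 and compound 2 in this assay are limits and not numbers: the limit of < 100000 nM in this assay, at which 2 of the 3 values shown sit.

The compounds shown leave open how large the change from a sulfur link to an oxygen link is, and in which direction it runs.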